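The source may report more compounds than this note shows. Statements on the series, on what has been measured and on what is new or still open speak of the compounds shown alone.

Compound 1 `Cc1nn(-c2ncnc3nc[nH]c23)c2c1C(OCc1cc(F)cc3c1OCOC3)CC(=O)N2` and compound 2 `Cc1nn(-c2ncnc3nc[nH]c23)c2c1C(OCc1ccc(Cl)cc1Cl)CC(=O)N2` share one core and differ only in the group carried on a saturated chain carbon bound to an oxygen on a saturated carbon. In a functional assay on HEK293 cells for agonist activity at G-protein coupled receptor 39 (Homo sapiens), read by scintillation proximity assay and inositol phosphate accumulation, with a stated time of 75 min (a higher number here means that more compound is needed for the effect, a lower number that less compound is needed), compound 1 gives 30 nM, and in this assay compound 2 gives 243 nM. Within the data shown here, the single comparison available is an 8.1-fold higher number from compound 1 to compound 2 (0.91 log units; beyond the scatter), so compound 2 stands with the highest of the two numbers, meaning more of it is needed for the effect than of compound 1.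

Compound 3 `Cc1nn(-c2ncnc3nc[nH]c23)c2c1C(NC(=O)c1ccccc1)CC(=O)N2` is the next compound to be tested. Compared with compound 2 the difference is benzamido in place of (2,4-dichlorobenzyl)oxy on a saturated ring carbon. Among the measured compounds shown here, no measured pair shows an exchange of this kind: the one step known, an 8.1-fold higher number from compound 1 to compound 2 (0.91 log units; beyond the scatter), swapped one aromatic group for another while keeping the same oxygen link, whereas here the link itself changes to an amide. That step therefore gives only a loose guide to how much such a group can move the number. For the measured compounds named here, with no closer precedent, compound 3 is expected to land near compound 2, with a step of a 2.1-fold higher number from compound 2 to compound 3 (0.31 log units; beyond the scatter), so that compound 3 is estimated at 500 nM, between 100 nM and 3000 nM.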

Compound 3, half-maximal effective concentration: 158 nM
Beside the measured number, compound 3's estimate is 3.2-fold (0.50 log units) above it; low and high end bracket the measured number.
By their numbers in this assay, from the lowest: compound 1; then compounds 3 and 2 (each within the scatter of the next).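

Placing benzamido instead of (2,4-dichlorobenzyl)oxy on this saturated ring carbon gives a 1.5-fold lower number from compound 2 to compound 3 (0.19 log units; within the scatter) in this assay, so the two numbers cannot be told apart. The oxygen link is therefore not needed at this position for a number in this range: a group joined through an amide, with one hydrogen-bond donor where the departing group has none and with no chlorine on its aromatic ring, reads the same within the scatter. Link, ring substitution and donor count all change in this one exchange, and nothing available shows what lies behind the match or whether these changes offset one another.

The compounds shown cannot separate the part played by the amide link from that of the unsubstituted aromatic ring, nor show whether an amide-linked group can reach the number of compound 1, 30 nM. Also open, on these data alone, is how this carbon would read with a benzamido ring bearing chlorine or fluorine, with a simple amine, or with a longer chain in place of benzamido.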